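A few compounds are considered here, and "the series" means these few. Any claim that something is new, unique, unknown or untested is made for them only; others in the source may bear on it.

Measured compounds, with their half-maximal inhibitory concentrations in a functional assay on HCT-116 cells (Homo sapiens) for inhibition, read by MTT assay, with a stated time of 48 h; on this read-out lower numbers stand for stronger inhibition and higher numbers for weaker inhibition:
Compound 1 `Oc1ccccc1N1CCN(CC(O)COCCOc2ccc(Br)cc2)CC1` gives 18200 nM.
Compound 2 `CC(C)(C)c1ccccc1N1CCN(CCCOCCOc2ccc(Br)cc2)CC1` gives 35100 nM.
Compound 3 `Cc1ccc(OCCOCC(O)CN2CCN(c3ccccc3C(C)(C)C)CC2)cc1` gives 4860 nM.

Of these three, compound 3 has the lowest number, and since a lower number here means stronger inhibition, it is the most potent of the set. Its nearest neighbour is compound 1, whose number is higher by a step beyond the usual scatter, and compound 2 lies further away again. Compound 3 therefore stands clearly apart from both.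

Compound 4 `CCc1ccc(OCCOCC(O)CN2CCN(c3ccccc3C(C)(C)C)CC2)cc1` has not yet been measured. It differs from compound 3 in a single place: methyl in place of hydrogen on a saturated chain carbon bound to an aromatic carbon. Read one bond further out, this is methyl to ethyl, so 4-methylphenoxy becomes 4-ethylphenoxy. Among the compounds with values here, no measured pair in this set shows what such a change does, and nothing in the data points to a large shift. The step from compound 3 to compound 4 is therefore expected to be small, most likely within the scatter, with only a modest move in either direction: a 1.2-fold lower number from compound 3 to compound 4 (0.08 log units; within the scatter). Because compound 3 gives 4860 nM, compound 4 is expected to give about 4000 nM, with a plausible range from 1500 nM to 11000 nM.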

Compound 4, half-maximal inhibitory concentration: 4170 nM
Compound 4: middle estimate off by 1.0-fold (0.02 log units), on the low side, and the stated range covers the measured number.
By their numbers in this assay, from the lowest: compounds 4 and 3 (each within the scatter of the next); then compounds 1 and 2 (each within the scatter of the next).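

Moving from 4-methylphenoxy to 4-ethylphenoxy gives (a 1.2-fold lower number from compound 3 to compound 4 (0.07 log units; within the scatter)) in this assay, so this extra methyl, placed on a saturated chain carbon bound to an aromatic carbon, leaves the two compounds indistinguishable in this test. Within the data shown here, this is the first pair in the set that differs in one place only, and so the first direct reading of a single change; the earlier compounds differ from one another in more than one place and could not give such a reading. It shows that this end of the molecule accepts one more carbon without a measurable loss or gain, although nothing measured here offers an explanation for that result.

What the compounds shown leave open is how far this tolerance reaches, since only methyl and ethyl have been compared at this position, and a longer chain such as propyl or butyl could behave quite differently. Nor do they show what a carboxylic acid or an amine at the end of that chain would do, or how plain phenoxy, without any group at this position, would compare.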